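This account rests on a few compounds, and the source may have more. Where it says the series, first, only, none or still open, it means among the compounds named here.

Measured compounds:
- compound 1, `COc1ccc(-c2cc(=O)n(C3CCCC3)nc2-c2ccc(OC)cc2)cc1`: 510 nM
- compound 2, `COc1ccc(-c2cc(=O)n(C3CC3)nc2-c2ccc(OC)cc2)cc1`: 7980 nM
- compound 3, `COc1ccc(-c2cc(=O)n(C(C)C)nc2-c2ccc(OC)cc2)cc1`: 1320 nM

All three share one core and differ only in the group carried on an aromatic nitrogen. In a functional assay on HL-60 cells (Homo sapiens) for inhibition (on this read-out higher numbers stand for weaker inhibition and lower numbers for stronger inhibition), compound 3 gives 1320 nM, the second highest of the three numbers: it sits a 2.6-fold higher number from compound 1 to compound 3 (0.41 log units; beyond the scatter) away from compound 1 and a 6.0-fold lower number from compound 2 to compound 3 (0.78 log units; beyond the scatter) away from compound 2, so both of its neighbours lie beyond the scatter.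

The next compound, compound 4, `COc1ccc(-c2cc(=O)n(CC3CCCC3)nc2-c2ccc(OC)cc2)cc1`, changes that same position: cyclopentylmethyl in place of isopropyl on an aromatic nitrogen.

Among the measured compounds shown here, two measured steps bear on this. Going a 16-fold higher number from compound 1 to compound 2 (1.19 log units; beyond the scatter), a smaller ring gave a much weaker result; going a 6.0-fold lower number from compound 2 to compound 3 (0.78 log units; beyond the scatter) and then a 2.6-fold higher number from compound 1 to compound 3 (0.41 log units; beyond the scatter), the five-membered ring gave the lowest number of the set. Across compounds 1, 2 and 3 the larger group at this nitrogen has so far gone with the lower number, with no compound against that. Compound 4 carries the largest group of the four, so a modest drop is expected in this assay, a 2.6-fold lower number from compound 3 to compound 4 (0.42 log units; beyond the scatter), landing near compound 1. The estimate for compound 4 is 500 nM, with a range from 150 nM to 1800 nM.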

Compound 4, half-maximal inhibitory concentration: 110 nM
Compound 4: middle estimate off by 4.5-fold (0.66 log units), on the high side, and the stated range ends above it.
By their numbers in this assay, from the lowest: compound 4; then compound 1; then compound 3; then compound 2.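

In this assay, among the compounds shown here, cyclopentylmethyl in place of isopropyl gives a far larger drop than the earlier compounds suggested (a 12-fold lower number from compound 3 to compound 4 (1.08 log units; beyond the scatter)), and the gap to the smallest group is wider still (a 73-fold lower number from compound 2 to compound 4 (1.86 log units; beyond the scatter)). The most telling comparison is with cyclopentyl, which carries the same ring directly on the aromatic nitrogen, whereas cyclopentylmethyl holds it through a methyl link; that link alone still lowers the number (a 4.6-fold lower number from compound 1 to compound 4 (0.67 log units; beyond the scatter)). So the ring need not sit directly on the nitrogen, and across all four compounds the larger group has gone with the lower number, with none against it.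

From the compounds shown here alone, whether this continues with a cyclohexylmethyl group, a longer chain such as cyclopentylethyl, or a benzyl group remains open. Nothing available explains why the methyl link lowers the number.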